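Swapping the aryl group on a two-compound imidazopyrazine series

The source may hold more compounds than are shown below. What is called first, only, known or untested is meant among the compounds shown, and "the series" means these compounds.

Of the compounds shown here, two have been measured in a functional assay on EKVX cells (Homo sapiens) for inhibition, read by sulforhodamine B assay, with a stated time of 48 h, tested at 10 uM; a lower number here means less inhibition, a higher number more inhibition at the concentration tested (going by the name of the read-out). Compound 1 `c1ccc2c(-c3cn4ccnc4c(-c4ccc5ncn(C6CCCCC6)c5c4)n3)cccc2c1`, which carries a naphthalen-1-yl group, gives 13.3%. Compound 2 `O=Cc1ccc(-c2cn3ccnc3c(-c3ccc4ncn(Cc5ccccc5)c4c3)n2)cc1` gives 20.9% in this assay. Within the data shown here, compound 2 is one of only two compounds measured, and its number and that of compound 1 lie within the usual scatter of each other, so no order between them can be claimed.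

Compound 3 `c1ccc(Cn2cnc3ccc(-c4nc(-c5cccc6ccccc56)cn5ccnc45)cc32)cc1` is not yet measured. It differs from compound 2 in one place: naphthalen-1-yl in place of 4-formylphenyl on an aromatic carbon. Among the measured compounds shown here, no step between two measured compounds that differ in only one place is available, so the size of this change can only be judged from the two values above. Because compound 1, which also carries naphthalen-1-yl, gives 13.3%, and because compound 2 gives 20.9%, the step of a number 4.9 percentage points lower from compound 2 to compound 3 (within the scatter) is expected to be small and not beyond the scatter. Compound 3 is therefore estimated at 16%, with a range from 3% to 30%.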

Compound 3, a percentage reported as inhibition, at one concentration (the size of the read-out at that concentration, not a potency): 24.6%
For compound 3 the middle estimate is 8.6 percentage points below the measured one; low and high end bracket the measured number.
By their numbers in this assay, from the lowest: compounds 1, 2 and 3 (each within the scatter of the next, the first and the last beyond it).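

Placing naphthalen-1-yl in place of 4-formylphenyl on this aromatic carbon gives a number 3.7 percentage points higher from compound 2 to compound 3 (within the scatter) in this assay, so this swap of one aryl group for another, which also removes the carbonyl, has no effect that can be told from the scatter. Among these compounds, with naphthalen-1-yl common to both compounds, benzyl in place of cyclohexyl on the aromatic nitrogen gives a number 11.3 percentage points higher from compound 1 to compound 3 (beyond the scatter), the only step so far that exceeds the scatter, and it arises at the nitrogen rather than at the aryl position. Nothing available accounts for either step.

From the compounds shown here alone, it remains open how an amine or a carboxylic acid on this aromatic carbon would read out in this assay. Going by these compounds, it is equally open whether a longer chain on the aromatic nitrogen would extend the step seen with benzyl.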